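The source may report more compounds than this note shows. Statements on the series, on what has been measured and on what is new or still open speak of the compounds shown alone.

In a functional assay on HCT-116 cells (Homo sapiens) for cytotoxicity, read by MTT assay, with a stated time of 72 h (on this read-out lower numbers stand for stronger inhibition and higher numbers for weaker inhibition), compound 3 `O=C(NCc1ccc(F)cc1)c1nc(Br)c2cccnc2c1NCc1ccccc1` gives > 20000 nM, which is a limit and not a number. It is the only one of the three measured compounds at the limit of > 20000 nM in this assay, at which 1 of the 3 values shown sits. The other two give numbers: compound 1 `Nc1ccc(Nc2c(C(=O)NCc3ccc(F)cc3)nc(Br)c3cccnc23)cc1` reads 7000 nM, and compound 2 `N[C@H]1CC[C@H](Nc2c(C(=O)NCc3ccc(F)cc3)nc(Br)c3cccnc23)CC1` reads 4000 nM. The gap between those two is small, a 1.8-fold lower number from compound 1 to compound 2 (0.24 log units; within the scatter).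

Compound 4 `NCCCCCCNc1c(C(=O)NCc2ccc(F)cc2)nc(Br)c2cccnc12` departs from compound 3 by 5-aminopentyl in place of phenyl on a saturated chain carbon bound to a nitrogen on an aromatic ring. In words, 5-aminopentyl stands in place of phenyl on a saturated chain carbon bound to a nitrogen on an aromatic ring, which also reads as benzyl to 6-aminohexyl.

Within the data shown here, two measured steps bear on this change: an at least 2.8-fold higher number from compound 1 to compound 3 (0.45 log units; beyond the scatter) and an at least 5.0-fold higher number from compound 2 to compound 3 (0.69 log units; beyond the scatter). Both end at the benzyl group of compound 3 and start from a group carrying an amino group, as the new chain does. Compound 4 differs from both compound 1 and compound 2 in having no ring in that group, so the match is only partial. A step of comparable size in this assay, towards a lower number, is therefore expected, running opposite to those two steps. The estimate amounts to an expected at least 4.4-fold lower number from compound 3 to compound 4 (0.64 log units; beyond the scatter). For compound 4 the estimated value is 4500 nM, with an expected range of 1500 nM to 13000 nM.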

Compound 4, half-maximal inhibitory concentration: > 10000 nM
Compound 4: a limit, no number; the forecaster's own chance of this, stated with the estimate: 15%; at least 2.2-fold (0.34 log units) between middle value and limit.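

In this assay, compound 4 shows that an amino group at the end of an open chain at this place, as 6-aminohexyl, does not match the 4-aminocyclohexyl group: an at least 2.5-fold higher number from compound 2 to compound 4 (0.39 log units; beyond the scatter). The comparison with the 4-aminophenyl group is less firm, since an at least 1.4-fold higher number from compound 1 to compound 4 (0.15 log units; that floor lies within the scatter) gives a floor that does not separate the two compounds. Compound 3 and compound 4 both end in limits, so the step between them cannot be read, and it remains unshown whether 6-aminohexyl does better or worse than benzyl: the limit of > 10000 nM in this assay, at which 1 of the 4 values shown sits.

The compounds shown leave open whether the ring itself or the distance of the amino group from the core sets the reading, which a shorter chain such as 3-aminopropyl or 4-aminobutyl could address. They also leave open whether the amino group is needed at all on the ring-bearing groups, a question that a plain cyclohexyl or a 4-hydroxycyclohexyl group at the same place would bear on.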